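Trifluoromethyl in place of a sulfur-fluorine group

The compounds below may be only part of what the source reports. "The series", "measured", "known", "first", "only" and "open" are said of these compounds alone.

- compound 1 `CC(O)(CSc1ccc(S(F)(F)(F)(F)F)cc1)C(=O)Nc1ccc(S(F)(F)(F)(F)F)cc1` gives 28000 nM (measured)
- compound 2 `CC(O)(CSc1cccc(S(F)(F)(F)(F)F)c1)C(=O)Nc1ccc(S(F)(F)(F)(F)F)cc1` gives 28200 nM (measured)

In a functional assay on VCaP cells (Homo sapiens) for antiproliferative activity, read by propidium iodide staining, with a stated time of 96 h (a lower number here means a stronger inhibitor, a higher number a weaker inhibitor), compound 1 and compound 2 lie within the scatter of each other, so neither ranks ahead and compound 1 stands level at the potent end of this short set. Compound 3 `CC(O)(CSc1ccc(C(F)(F)F)cc1)C(=O)Nc1ccc(S(F)(F)(F)(F)F)cc1` keeps the core of compound 1 but carries trifluoromethyl on an aromatic carbon, para to a large group (a group of 4 heavy atoms (1 carbon, 3 fluorine; no ring) in place of a group of 6 heavy atoms (5 fluorine, 1 sulfur; no ring), on an aromatic carbon). Among the measured compounds shown here, no measured step covers this change, so no shift beyond the scatter is expected in either direction. The estimated 1.1-fold lower number from compound 1 to compound 3 (0.05 log units; within the scatter) is correspondingly small. Compound 3 is expected at 25000 nM (range 10000 nM to 60000 nM) in this assay when measured.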

Compound 3, half-maximal inhibitory concentration: 24800 nM
Estimate against measurement, compound 3: 1.0-fold (0.00 log units) above, within the range that was stated.
By their numbers in this assay, from the lowest: compounds 3, 1 and 2 (each within the scatter of the next).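

At this aromatic carbon, para to a large group, the first measured step gives a 1.1-fold lower number from compound 1 to compound 3 (0.05 log units; within the scatter) in this assay. Trifluoromethyl, with its 4 heavy atoms, thus stands in place of the group of 6 heavy atoms without a shift beyond the scatter. No available measurement bears on this result.

From the compounds shown here alone, whether a nitrile, an amine or a carboxylic acid at this carbon would move the number beyond the scatter remains open. So does the outcome of the same exchange at the other sulfur-fluorine group of compound 1.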